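Isopropyl to Phenyl: Expected Potency of Compound 4

The source may hold more compounds than are shown below. What is called first, only, known or untested is meant among the compounds shown, and "the series" means these compounds.

Compound 1, `C[C@H](Oc1ccc(S(C)(=O)=O)cc1C(=O)N1Cc2ccc(N3CCN(C)CC3)cc2C1)C(F)(F)F`, gives 2080 nM in an assay on CHO cells for inhibition of sodium- and chloride-dependent glycine transporter 1 (Homo sapiens), read by scintillation counting; on this read-out lower numbers stand for an effect already at smaller amounts and higher numbers for an effect only at larger amounts of compound.
Compound 2, `C[C@H](Oc1ccc(S(C)(=O)=O)cc1C(=O)N1Cc2ccc(-c3ccccn3)cc2C1)C(F)(F)F`, gives 84 nM.
Compound 3, `CC(C)COc1ccc(S(C)(=O)=O)cc1C(=O)N1Cc2cc(C(F)(F)F)cnc2C1`, gives 30 nM.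

Compound 3 shows the lowest number of the three; compound 2 comes nearest, and compound 1 lies farthest. Among the compounds with values here, the one measured step, a 25-fold lower number from compound 1 to compound 2 (1.39 log units; beyond the scatter), comes from pyridin-2-yl in place of 4-methylpiperazin-1-yl on an aromatic carbon. Compound 4, `CS(=O)(=O)c1ccc(OCc2ccccc2)c(C(=O)N2Cc3cc(C(F)(F)F)cnc3C2)c1`, is not yet measured. It differs from compound 3 by phenyl in place of isopropyl on a saturated chain carbon bound to an oxygen on an aromatic ring; put another way, isobutoxy becomes benzyloxy. Within the data shown here, no measured step touches this part of the molecule, so there is no direct guidance, and nothing argues for a large change. Compound 4 is therefore expected to stay close to compound 3, with an estimated 1.3-fold higher number from compound 3 to compound 4 (0.12 log units; within the scatter) in this assay. The estimated value for compound 4 is 40 nM, within a range from 12 nM to 130 nM.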

Compound 4, half-maximal effective concentration: 805 nM
Compound 4: middle estimate off by 20-fold (1.30 log units), on the low side; measured number outside the range, above it.
By their numbers in this assay, from the lowest: compound 3; then compound 2; then compound 4; then compound 1.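

Phenyl in place of isopropyl gives a 27-fold higher number from compound 3 to compound 4 (1.43 log units; beyond the scatter) in this assay. Within the data shown here, this is the only measured step at this part of the molecule, and it shows that the group on this saturated chain carbon strongly affects the read-out. No evidence on the cause of this large change is at hand.

The compounds shown leave open whether the aromatic ring itself or simply the larger group goes with the higher number, which a cyclohexyl group at this place could help separate. As far as these compounds go, how a longer chain would behave here also remains open.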